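The source may report more compounds than this note shows. Statements on the series, on what has been measured and on what is new or still open speak of the compounds shown alone.

Measured in a functional assay on HCT-116 cells (Homo sapiens) for antiproliferative activity, read by MTT assay, with a stated time of 72 h; on this read-out lower numbers stand for stronger inhibition and higher numbers for weaker inhibition:

Compound 1 `O=S1(=O)C=Cc2ccc(Nc3ccc(Cl)c(Cl)c3)cc21`: 2470 nM
Compound 2 `O=S1(=O)C=Cc2cccc(Nc3ccc(OC(F)(F)F)cc3)c21`: 2380 nM

Compound 2, at 2380 nM, stands level with compound 1, at 2470 nM. The two values lie within the scatter of each other, so neither can be ranked above the other in this assay. The next compound to be read is compound 3 `COc1ccc(Nc2cccc3c2S(=O)(=O)C=C3)cc1`. It keeps the core of compound 2 and has methyl in place of trifluoromethyl on an oxygen on an aromatic ring, a change that can also be read as trifluoromethoxy to methoxy.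

Among the measured compounds shown here, no measured pair in this small set shows what such a change does, so the value of compound 2, 2380 nM, is the only anchor. A small move toward a higher number is expected in this assay, meaning slightly weaker inhibition, but not one beyond the scatter. The estimated step is a 1.5-fold higher number from compound 2 to compound 3 (0.17 log units; within the scatter). With so little evidence, the expected range stays wide. For compound 3 the estimated value is 3500 nM, expected to fall between 1100 nM and 10000 nM.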

Compound 3, half-maximal inhibitory concentration: 1990 nM
Compound 3: the middle estimate sits 1.8-fold (0.25 log units) above what was measured, within the range that was stated.
By their numbers in this assay, from the lowest: compounds 3, 2 and 1 (each within the scatter of the next).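

In this assay, putting methyl in place of trifluoromethyl on an oxygen on an aromatic ring gives a 1.2-fold lower number from compound 2 to compound 3 (0.08 log units; within the scatter). Among the compounds shown here, this is the first measured pair in the set that isolates a single change, and it places compound 2 and compound 3 level: trifluoromethoxy and methoxy cannot be told apart by this read-out on this core, even though the four heavy atoms of trifluoromethyl give way to the single carbon of methyl. The data shown offer no independent measurement that could account for this result.

With only these two groups shown on that oxygen, it stays open whether a longer chain there, or an amine or a carboxylic acid in place of the methoxy, would shift the number beyond the scatter. Compound 1 differs from compound 2 and compound 3 in more than one place, so the separate contributions of its two chlorines and of where its amine joins the core also remain unresolved.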